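A few compounds are considered here, and "the series" means these few. Any claim that something is new, unique, unknown or untested is made for them only; others in the source may bear on it.

Compound 3 `Cc1cc(OCc2c(-c3c(Cl)cn(C)c(=O)c3Cl)noc2C(C)C)ccc1-c1ccc2c(C(=O)O)cn(C)c2c1` gives the highest number of the three measured compounds in an assay on isolated protein for displacement of a labelled ligand from Bile acid receptor (Homo sapiens), read by scintillation proximity assay and radioligand binding (on this read-out lower numbers stand for stronger inhibition and higher numbers for weaker inhibition), at 2750 nM; compound 1 `Cc1cc(OCc2c(-c3cc[nH]c(=O)c3Cl)noc2C(C)C)ccc1-c1ccc2c(C(=O)O)cn(C)c2c1` gives 1100 nM and compound 2 `COc1ccc(Cl)c(-c2noc(C(C)C)c2COc2ccc(-c3ccc4c(C(=O)O)cn(C)c4c3)c(C)c2)n1` gives 310 nM. Compound 4 `Cc1cc(OCc2c(-c3[nH]c(=O)ccc3Cl)noc2C(C)C)ccc1-c1ccc2c(C(=O)O)cn(C)c2c1` differs from compound 3 by a group of 8 heavy atoms (5 carbon, 1 nitrogen, 1 oxygen, 1 chlorine; one six-membered aromatic ring with 1 hetero atom) in place of a group of 10 heavy atoms (6 carbon, 1 nitrogen, 1 oxygen, 2 chlorine; one six-membered aromatic ring with 1 hetero atom), on an aromatic carbon. Within the data shown here, the only step that speaks to this is a 2.5-fold higher number from compound 1 to compound 3 (0.40 log units; beyond the scatter), where the same pattern of extra chlorine and ring-nitrogen methyl was added to a group of the same size as the one entering here, though the group in compound 4 is joined to the core through a different ring carbon than in compound 1. The reverse of that step suggests a modest drop in this assay for compound 4, and it is therefore expected to give about 1500 nM, between 500 nM and 5000 nM, a change of a 1.8-fold lower number from compound 3 to compound 4 (0.26 log units; within the scatter).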

Compound 4, half-maximal inhibitory concentration: 4130 nM
The estimate for compound 4 lay 2.8-fold (0.44 log units) below the measured number; the measured number falls inside the stated range.
By their numbers in this assay, from the lowest: compound 2; then compound 1; then compounds 3 and 4 (each within the scatter of the next).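

In this assay, the new group on the aromatic carbon of the five-membered ring gives a 3.8-fold higher number from compound 1 to compound 4 (0.57 log units; beyond the scatter), so two groups of equal size, joined through different ring carbons, are not interchangeable here. Compound 4 cannot be told apart from compound 3, with a 1.5-fold higher number from compound 3 to compound 4 (0.18 log units; within the scatter), even though the group in compound 3 carries an extra chlorine and a ring-nitrogen methyl. The widest gap at this position is a 13-fold higher number from compound 2 to compound 4 (1.12 log units; beyond the scatter). The compounds shown leave open how an amine in place of the methoxy group of compound 2 would read, and nothing available explains these differences.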